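The compounds below may be only part of what the source reports. "The series", "measured", "known", "first", "only" and "open" are said of these compounds alone.

Of the compounds shown here, three sharing one core have been measured in a functional assay (aorta) with Rattus norvegicus as the target; on this read-out higher numbers stand for weaker inhibition and lower numbers for stronger inhibition. Compound 1 `CCCCN(CCCC)CCCOc1ccc(S(=O)(=O)c2c(C(C)C)cn3ccccc23)cc1`, which carries an isopropyl group, gives 21.6 nM. Compound 2 `CCCCN(CCCC)CCCOc1ccc(S(=O)(=O)c2c(C(C)(C)C)cn3ccccc23)cc1`, which carries a tert-butyl group, gives 51.9 nM. Compound 3 `CCCCN(CCCC)CCCOc1ccc(S(=O)(=O)c2c(C)cn3ccccc23)cc1`, with a methyl group in that place, gives 162 nM, the highest number of the three and so the weakest inhibition among them.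

Compound 4 `CCCCN(CCCC)CCCOc1ccc(S(=O)(=O)c2c(CC)cn3ccccc23)cc1` departs from compound 3 by a single change, methyl in place of hydrogen on a saturated chain carbon bound to an aromatic carbon, which turns methyl to ethyl.

Among the measured compounds shown here, three measured steps bear on this change. Going to methyl from isopropyl gives a 7.5-fold higher number from compound 1 to compound 3 (0.88 log units; beyond the scatter), and going to methyl from tert-butyl gives a 3.1-fold higher number from compound 2 to compound 3 (0.49 log units; beyond the scatter). Both steps are modest, and both suggest that a group larger than methyl can bring the number down. Adding a methyl does not always do so, however, since the step from isopropyl to tert-butyl gives a 2.4-fold higher number from compound 1 to compound 2 (0.38 log units; beyond the scatter). Ethyl has not been tested, so compound 4 is expected to fall between the methyl and isopropyl compounds, with a modest drop from compound 3. The expected change is a 2.7-fold lower number from compound 3 to compound 4 (0.43 log units; beyond the scatter). For compound 4 the estimated value is 60 nM, with an expected range from 25 nM to 140 nM.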

Compound 4, half-maximal inhibitory concentration: 31.3 nM
Beside the measured number, compound 4's estimate is 1.9-fold (0.28 log units) above it, and the stated range covers the measured number.
By their numbers in this assay, from the lowest: compounds 1, 4 and 2 (each within the scatter of the next, the first and the last beyond it); then compound 3.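

In this assay, the methyl in place of hydrogen on a saturated chain carbon bound to an aromatic carbon gives a 5.2-fold lower number from compound 3 to compound 4 (0.71 log units; beyond the scatter) and so shows that this single added methyl is enough to leave the level of compound 3 behind. Ethyl cannot be told apart from either branched group, with a 1.7-fold lower number from compound 2 to compound 4 (0.22 log units; within the scatter) and a 1.4-fold higher number from compound 1 to compound 4 (0.16 log units; within the scatter) both lying within the scatter, so among these compounds branching is not required to reach that level. The earlier compounds shown here showed this change only as a step up in number, and compound 4 now shows that its direction depends on the group that receives the methyl: the same change on two cores in this assay, a 2.4-fold higher number (0.38 log units; beyond the scatter) from compound 1 to compound 2 and a 5.2-fold lower number (0.71 log units; beyond the scatter) from compound 3 to compound 4, 12-fold (1.09 log units) apart, beyond the scatter of two such steps.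

What the compounds shown leave open is how far this position tolerates other groups, such as a longer chain like propyl or butyl, a small ring like cyclopropyl, or a chain that ends in a hydroxyl or an amine. They also leave open what plain hydrogen at this position would give, and whether the order seen here would carry over to any other read-out.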